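This account rests on a few compounds, and the source may have more. Where it says the series, first, only, none or still open, it means among the compounds named here.

Compound 1 `CCCC/C=C\CCCCCCCCCC1(O)CC(=O)c2c(O)cc(OCOC)cc2O1` gives 43200 nM
Compound 2 `CC/C=C\C/C=C\C/C=C\CCCCCCCc1cc(=O)c2c(O)cc(OCOC)c(C)c2o1` gives 17500 nM

In a functional assay on MCF7 cells (Homo sapiens) for antiproliferative activity, read by MTT assay (on this read-out higher numbers stand for weaker inhibition and lower numbers for stronger inhibition), compound 2 at 17500 nM holds the lower of the two numbers, and its gap to compound 1 lies beyond the usual scatter. Compound 3 `CC/C=C\C/C=C\C/C=C\CCCCCCCc1cc(=O)c2c(O)cc(OCOC)cc2o1` differs from compound 2 in one place only: hydrogen in place of methyl on an aromatic carbon (hydrogen in place of methyl on an aromatic carbon, ortho to the methoxymethoxy group). Within the data shown here, no pair of measured compounds shows this change, so the data give no direct guide to its size. The expectation therefore starts from compound 2 at 17500 nM and assumes no step beyond the scatter in this assay, with a slight lean toward a higher number. The expected change is a 1.3-fold higher number from compound 2 to compound 3 (0.10 log units; within the scatter) and would stay within the scatter. For compound 3 the estimated value is 22000 nM, with an expected range from 10000 nM to 45000 nM.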

Compound 3, half-maximal inhibitory concentration: 17500 nM
Beside the measured number, compound 3's estimate is 1.3-fold (0.10 log units) above it, within the range that was stated.
By their numbers in this assay, from the lowest: compounds 2 and 3 (each within the scatter of the next); then compound 1.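

In this assay, replacing the methyl on the aromatic carbon ortho to the methoxymethoxy group with hydrogen gives no change at the digits printed from compound 2 to compound 3 (within the scatter). Among these compounds, this is the first direct reading of this position, since compound 1 and compound 2 differ in more than one place and could not isolate it; for this pair, the methyl can be removed without any change that stands out from ordinary assay variation. No accompanying measurement offers an explanation for this result.

As far as these compounds go, it remains open whether a different group on this same aromatic carbon, such as an amine, a chlorine atom or a carboxylic acid, would move the number beyond the scatter. From the compounds shown here alone, it is also open whether the same swap of methyl for hydrogen would read the same in compounds carrying a shorter chain.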